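Swapping 1-acetylazetidin-3-yl for 1-acetylpyrrolidin-3-yl

A few compounds are considered here, and "the series" means these few. Any claim that something is new, unique, unknown or untested is made for them only; others in the source may bear on it.

- compound 1 `CN1CCC(NC(=O)c2ccncc2Nc2cc(-c3ccc4ccn(C)c4c3)c3nccnc3c2)CC1`: > 1 h (a limit of the assay, not a number)
- compound 2 `CC(=O)N1CC(NC(=O)c2ccncc2Nc2cc(-c3ccc4ccn(C)c4c3)c3nccnc3c2)C1`: 0.817 h

Going by the values given here, in an ADME assay on microsomes from liver (Mus musculus, strain CD-1) for metabolic stability, read by LC-MS, tested at 2 uM (a lower number here means that the compound disappears faster, a higher number that the compound lasts longer), compound 2 gives 0.817 h, the only true number so far. The other reading, for compound 1, is only a limit. Compound 3 `CC(=O)N1CCC(NC(=O)c2ccncc2Nc2cc(-c3ccc4ccn(C)c4c3)c3nccnc3c2)C1` differs from compound 2 in a single place: 1-acetylpyrrolidin-3-yl in place of 1-acetylazetidin-3-yl on an amide-type nitrogen. Put simply, 1-acetylpyrrolidin-3-yl stands in place of 1-acetylazetidin-3-yl on an amide-type nitrogen. Among the compounds with values here, only one measured step changes this same place: an at least 1.2-fold lower number from compound 1 to compound 2 (0.08 log units; that floor lies within the scatter). That step starts from a limit and offers no sign of a real change, so it gives weak guidance on size or direction. No step beyond the scatter is therefore expected in this assay. The expected step, a 1.0-fold higher number from compound 2 to compound 3 (0.02 log units; within the scatter), is an estimate resting on this single comparison. The estimated half-life of compound 3 is 0.85 h, with an expected range from 0.42 h to 1.7 h.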

Compound 3, half-life: 0.667 h
Compound 3: middle estimate off by 1.3-fold (0.11 log units), on the high side; measured number inside the range.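

In this assay, going by these compounds alone, the first comparison at this amide-type nitrogen between two true numbers is a 1.2-fold lower number from compound 2 to compound 3 (0.09 log units; within the scatter). Between the four-membered ring of 1-acetylazetidin-3-yl and the five-membered ring of 1-acetylpyrrolidin-3-yl, the half-life therefore shows no difference beyond the usual scatter. The other new step, an at least 1.4-fold lower number from compound 1 to compound 3 (0.17 log units; that floor lies within the scatter), gives only a floor and shows no real difference either, because the reading of compound 1 is a limit and not a number: the limit of > 1 h in this assay, at which 1 of the 3 values shown sits.

From the compounds shown here alone, whether compound 1 truly lasts longer than the two acetylated compounds stays open, as its actual half-life is unknown. Also open, going by these compounds, is how this position responds to 1-acetylpiperidin-4-yl or 1-methylpyrrolidin-3-yl, groups that would separate the role of the acetyl group from that of ring size.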